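A benzyl substituent swap in an aldehyde dehydrogenase series

A few compounds are considered here, and "the series" means these few. Any claim that something is new, unique, unknown or untested is made for them only; others in the source may bear on it.

Of the compounds shown here, three share one core and have been tested in an assay on isolated protein for inhibition of aldehyde dehydrogenase 1A1 (Homo sapiens), read by spectrophotometry, tested at 10 uM; a higher number here means more inhibition at the concentration tested (going by the name of the read-out), a lower number less inhibition. Compound 1 `CCC(=O)N1CCN(Cc2nc3ccccc3n2Cc2cccc(C)c2)CC1` gives 85.1%, compound 3 `Cc1ccc(C(=O)N2CCN(Cc3nc4ccccc4n3Cc3cccc(C)c3)CC2)cc1` gives 64.9%, and compound 2 `Cc1ccccc1Cn1c(CN2CCN(C(=O)C3CC3)CC2)nc2ccccc21` gives 29.1%, the lowest of the three values. Among the compounds with values here, the one single-point step recorded, a number 20.2 percentage points lower from compound 1 to compound 3 (beyond the scatter), concerns the carbonyl side of the molecule and does not touch the benzyl group; compounds 1 and 3 each differ from compound 2 in more than one place, so their higher values can only be noted, not traced to one change.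

The next compound, compound 4 `O=C(C1CC1)N1CCN(Cc2nc3ccccc3n2Cc2ccc(Cl)cc2)CC1`, carries the change (4-chlorophenyl in place of 2-methylphenyl on a saturated chain carbon bound to an aromatic nitrogen). Within the data shown here, no measured step bears directly on this change, and the data give no guide to its direction. Given that compound 2 sits at the low end with 29.1% and the other two measured compounds lie well above it, a rise is expected but with wide uncertainty; the expected step is a number 15.9 percentage points higher from compound 2 to compound 4 (beyond the scatter). Compound 4 is therefore estimated at 45%, with a range from 10% to 80% in this assay.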

Compound 4, a percentage reported as inhibition, at one concentration (the size of the read-out at that concentration, not a potency): 56.6%
Compound 4: the middle estimate sits 11.6 percentage points below what was measured, and the stated range covers the measured number.
By their numbers in this assay, from the lowest: compound 2; then compounds 4 and 3 (each within the scatter of the next); then compound 1.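

Within the data shown here, compound 2 to compound 4 is the first reading in this assay of a single change at this position, and 4-chlorophenyl in place of 2-methylphenyl on a saturated chain carbon bound to an aromatic nitrogen gives a number 27.5 percentage points higher from compound 2 to compound 4 (beyond the scatter) with the rest of the molecule held the same. The read-out therefore responds to the benzyl group as well as to the carbonyl side, even though the two groups match in their counts of heavy atoms, hydrogen-bond donors and hydrogen-bond acceptors. Nothing measured here accounts for the size or direction of this step.

The change replaces the methyl with a chlorine and also moves the substituent, so these two contributions cannot be separated from this pair alone. As far as these compounds go, a 2-chlorophenyl group would bear on that question, and how a carboxylic acid or an amine on the benzyl ring would read remains open.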